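The source may hold more compounds than are shown below. What is called first, only, known or untested is meant among the compounds shown, and "the series" means these compounds.

Of the compounds shown here, three have been tested in a functional assay on HL-60 cells (Homo sapiens) for antiproliferative activity, read by MTT assay, with a stated time of 72 h (a higher number here means a weaker inhibitor, a lower number a stronger inhibitor), so far. Compound 2 `COc1cc(-n2ncnc2-c2ccc(OC(C)C)cc2)cc(OC)c1OC` gives 700 nM. Compound 1 `COc1cc(-n2ncnc2-c2cccc([N+](=O)[O-])c2)cc(OC)c1OC` reaches only a limit of the assay, > 10000 nM. Compound 3 `COc1cc(-n2ncnc2-c2ccc(F)cc2)cc(OC)c1OC` likewise reaches only a limit, > 10000 nM. Going by the values given here, the one measured step with a single change, an at least 14-fold higher number from compound 2 to compound 3 (1.15 log units; beyond the scatter), shows that swapping the isopropoxy for a fluorine takes the compound from a measurable number to the edge of the assay; it rests on (the limit of > 10000 nM in this assay, at which 2 of the 3 values shown sit), where compound 3 stands together with compound 1.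

Compound 4 `COc1cc(-n2ncnc2-c2cccc(F)c2)cc(OC)c1OC` differs from compound 3 in only one place: 3-fluorophenyl in place of 4-fluorophenyl on an aromatic carbon. Among the compounds with values here, the single measured step does not touch this change, since it swaps one group for another rather than moving the same group around the ring. Within the data shown here, compound 1 carries its own group at the same ring position that the fluorine takes in compound 4, and compound 1 also sits at the limit; no step between compound 1 and compound 4 has been measured, so this is only what its value shows.

With nothing pointing to a gain, compound 4 is expected to stay near where compound 3 sits, an estimated step of a number no higher from compound 3 to compound 4 (the limit leaves the size open). The estimate for compound 4 in this assay is 10000 nM, within a range from 3000 nM to 30000 nM.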

Compound 4, half-maximal inhibitory concentration: > 10000 nM
Compound 4 was reported as a limit (the forecaster's own chance of this, stated with the estimate: 75%); the middle value sits exactly at the limit.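

Compound 4 also reaches only a limit of the assay, so its steps from compound 3 and from compound 1 cannot be read, since all three sit at that limit: the limit of > 10000 nM in this assay, at which 3 of the 4 values shown sit.

The compounds shown leave open whether 3-fluorophenyl in place of 4-fluorophenyl changes the result in this assay at all, and what actual number each of these three compounds would give.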